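The compounds below may be only part of what the source reports. "The series", "measured", "known", "first", "only" and "open" are said of these compounds alone.

In a functional assay on the whole organism with Mus musculus as the target, in the rotarod test (on this read-out higher numbers stand for an effect only at larger amounts of compound and lower numbers for an effect already at smaller amounts), compound 3 `NC(=O)/C=C1\CCc2ccc(Cl)cc21` gives 221 mg/kg. Compound 1 `NC(=O)/C=C1\CCc2c(F)cc(F)cc21` gives 138 mg/kg, and these two values lie within the usual scatter of each other. In this assay, compound 2 `CC(C)NC(=O)/C=C1\CCc2ccc(F)cc21` gives only a limit, > 100 mg/kg. Compound 4 `NC(=O)/C=C1\CCc2ccc(F)cc21` differs from compound 3 in one place: fluoro in place of chloro on an aromatic carbon. Within the data shown here, no measured pair shows this swap on its own, so the best guide is compound 3 itself, at 221 mg/kg, and no step beyond the scatter is expected in this assay. The expected move, a 1.3-fold lower number from compound 3 to compound 4 (0.11 log units; within the scatter), is small. Compound 4 is estimated at 170 mg/kg, with an expected range of 90 mg/kg to 320 mg/kg.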

Compound 4, dose for half-maximal effect: 90 mg/kg
The estimate for compound 4 lay 1.9-fold (0.28 log units) above the measured number; low and high end bracket the measured number.
By their numbers in this assay, from the lowest: compounds 4, 1 and 3 (each within the scatter of the next, the first and the last beyond it).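

Among these compounds, on this aromatic carbon, fluoro in place of chloro gives a 2.5-fold lower number from compound 3 to compound 4 (0.39 log units; beyond the scatter) in this assay and is the first step here to pass the scatter, so the choice of halogen at this carbon counts. Hydrogen in place of fluoro gives a 1.5-fold lower number from compound 1 to compound 4 (0.19 log units; within the scatter) and so shows no clear change. Compound 2 has only a limit, so hydrogen in place of isopropyl on the amide-type nitrogen gives an at least 1.1-fold lower number from compound 2 to compound 4 (0.04 log units; that floor lies within the scatter) as a floor: the limit of > 100 mg/kg in this assay, at which 1 of the 4 values shown sits.

On these data alone, how a bromo or a methoxy at this carbon would compare stays open.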